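From a Carboxylic Chain to a Piperidine Ring

The source may report more compounds than this note shows. Statements on the series, on what has been measured and on what is new or still open speak of the compounds shown alone.

Of the compounds shown here, three built on one shared core have been measured in an assay on U2OS cells for inhibition of secreted frizzled-related protein 1 (Homo sapiens), read by a luciferase reporter, with a stated time of 18 h; on this read-out lower numbers stand for an effect already at smaller amounts and higher numbers for an effect only at larger amounts of compound. Compound 1 `O=C(c1ccc(Cl)cc1)N1CCC(NS(=O)(=O)c2cc(S(=O)(=O)c3ccccc3)ccc2C(F)(F)F)CC1` gives 1800 nM, compound 2 `O=S(=O)(NC1CCN(S(=O)(=O)c2ccccc2)CC1)c1cc(S(=O)(=O)c2ccccc2)ccc1C(F)(F)F` gives 210 nM, and compound 3 `O=C(O)CCCC(=O)N1CCC(NS(=O)(=O)c2cc(S(=O)(=O)c3ccccc3)ccc2C(F)(F)F)CC1` gives 570 nM. Compound 3 thus stands second highest of the three numbers: the step of a 3.2-fold lower number from compound 1 to compound 3 (0.50 log units; beyond the scatter) separates it from compound 1, which lies furthest away, and the step of a 2.7-fold higher number from compound 2 to compound 3 (0.43 log units; beyond the scatter) from compound 2, which lies nearest. Compound 4 `O=C(CC1CCNCC1)N1CCC(NS(=O)(=O)c2cc(S(=O)(=O)c3ccccc3)ccc2C(F)(F)F)CC1` has not yet been measured; it differs from compound 3 by piperidin-4-yl in place of 2-carboxyethyl on a saturated chain carbon bound to a carbonyl carbon. Among the compounds with values here, no measured step touches exactly this part of the molecule. Within the data shown here, the steps of an 8.6-fold lower number from compound 1 to compound 2 (0.93 log units; beyond the scatter) and a 2.7-fold higher number from compound 2 to compound 3 (0.43 log units; beyond the scatter) each exchange the whole group on the ring nitrogen, and they show only that changes at this end of the core move the number by modest amounts in either direction. The step of a 1.4-fold lower number from compound 3 to compound 4 (0.15 log units; within the scatter) that this estimate means is therefore expected to be small, with wide uncertainty around it. Compound 4 is estimated at 400 nM, within a range from 100 nM to 2000 nM.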

Compound 4, half-maximal effective concentration: 210 nM
For compound 4 the middle estimate is 1.9-fold (0.28 log units) above the measured one; low and high end bracket the measured number.
By their numbers in this assay, from the lowest: compounds 2 and 4 (each within the scatter of the next); then compound 3; then compound 1.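

In this assay, within the data shown here, putting piperidin-4-yl in place of 2-carboxyethyl on a saturated chain carbon bound to a carbonyl carbon gives a 2.7-fold lower number from compound 3 to compound 4 (0.43 log units; beyond the scatter) and so shows, as no earlier step did, that the end of this chain can shift the number while the carbonyl stays in place. The same end group also matches a phenylsulfonyl on the amine nitrogen in a ring, with no change at the digits printed from compound 2 to compound 4 (within the scatter) and, against the 4-chlorophenyl on the carbonyl carbon, an 8.6-fold lower number from compound 1 to compound 4 (0.93 log units; beyond the scatter) as the result. No measurement shown here explains these shifts.

Going by these compounds, it remains open whether the piperidine ring as a whole matters or only its nitrogen. An open-chain amine such as 2-aminoethyl, or a longer chain carrying the same ring, could help separate the two.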